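Compound 4: a new aniline on a short chain

This account rests on a few compounds, and the source may have more. Where it says the series, first, only, none or still open, it means among the compounds named here.

- Compound 1 `COc1cc2ncnc(Nc3cccc(Cl)c3)c2cc1OCCC(=O)NO` gives > 100000 nM
- Compound 2 `COc1cc2ncnc(Nc3cccc(Br)c3)c2cc1OCCC(=O)NO` gives > 100000 nM
- Compound 3 `COc1cc2ncnc(Nc3cccc(Br)c3)c2cc1OCCCCCC(=O)NO` gives 2800 nM

In a functional assay on MCF7 cells (Homo sapiens) for antiproliferative activity, read by MTT assay, with a stated time of 48 h (on this read-out lower numbers stand for stronger inhibition and higher numbers for weaker inhibition), compound 2 gives > 100000 nM, which is a limit and not a number. Compound 1 gives > 100000 nM, also a limit. Together they sit at the limit of > 100000 nM in this assay, at which 2 of the 3 values shown sit.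

Compound 4 `COc1cc2ncnc(Nc3ccc(Cl)cc3Cl)c2cc1OCCC(=O)NO` carries 2,4-dichlorophenyl in place of 3-bromophenyl on a nitrogen on an aromatic ring. The closest measured change in this group is a step that the two limits leave unreadable from compound 1 to compound 2, so it gives no size to go on. Among the compounds with values here, the only readable change is an at least 35-fold lower number from compound 2 to compound 3 (1.55 log units; beyond the scatter), and it lies in the chain rather than in this group. Compound 4 keeps the chain of compound 2, so the large gain of compound 3 at 2800 nM is not expected to carry over.

No step beyond the scatter is expected in this assay, and the estimated size is a number no higher from compound 2 to compound 4 (the limit leaves the size open). Compound 4 is expected near 100000 nM, with an estimated range from 30000 nM to 200000 nM.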

Compound 4, half-maximal inhibitory concentration: 95000 nM
The estimate for compound 4 lay 1.1-fold (0.02 log units) above the measured number; low and high end bracket the measured number.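

In this assay, 2,4-dichlorophenyl in place of the halogenated phenyl of the earlier short-chain compounds gives an at least 1.0-fold lower number from compound 2 to compound 4 (0.02 log units; that floor lies within the scatter) and an at least 1.0-fold lower number from compound 1 to compound 4 (0.02 log units; that floor lies within the scatter). Within the data shown here, compound 4 therefore supplies the only actual number on this short chain, but with both floors inside the scatter, it shows no readable gain from a second chlorine or from this new arrangement on the phenyl ring. Compound 1 and compound 2 each stay at a limit and not a number: the limit of > 100000 nM in this assay, at which 2 of the 4 values shown sit.

As far as these compounds go, what 2,4-dichlorophenyl does on the longer chain of compound 3 stays open, and there a change in this group could be read against the 2800 nM of compound 3. Also open, from the compounds shown here alone, is how a phenyl ring carrying a methoxy or an amine would behave on either chain.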